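The source may report more compounds than this note shows. Statements on the series, on what has been measured and on what is new or still open speak of the compounds shown alone.

Of the compounds shown here, three built on one shared core have been measured in a functional assay on HeLa cells (Homo sapiens) for cytotoxicity, read by MTT assay, with a stated time of 72 h; on this read-out lower numbers stand for stronger inhibition and higher numbers for weaker inhibition. Compound 1, `O=C1c2cccc([N+](=O)[O-])c2NC[C@@]12[C@H](c1ccc(Cl)cc1)[C@@H](c1ccccc1)N[C@]21C(=O)Nc2ccc(Br)cc21`, gives 23000 nM in this assay. Compound 2, `O=C1c2cccc([N+](=O)[O-])c2NC[C@@]12[C@H](c1ccc(Br)cc1)[C@@H](c1ccccc1)N[C@]21C(=O)Nc2ccc(Br)cc21`, gives 25000 nM. Compound 3, `O=C1c2cccc([N+](=O)[O-])c2NC[C@@]12[C@H](c1ccc(Cl)cc1)[C@@H](c1ccccc1)N[C@]21C(=O)Nc2ccc(F)cc21`, gives 25000 nM. The step of a 1.1-fold higher number from compound 1 to compound 2 (0.04 log units; within the scatter) goes with the change (bromo in place of chloro on an aromatic carbon). The step of a 1.1-fold higher number from compound 1 to compound 3 (0.04 log units; within the scatter) goes with fluoro in place of bromo on an aromatic carbon, which is also how the core of compound 3 differs from the core of compound 1. Compound 2 and compound 3 show the same number at the digits recorded, and all three values sit close to one another.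

Compound 4, `O=C1c2cccc([N+](=O)[O-])c2NC[C@@]12[C@H](c1ccc(Br)cc1)[C@@H](c1ccccc1)N[C@]21C(=O)Nc2ccc(F)cc21`, has not yet been measured. It differs from compound 3 by bromo in place of chloro on an aromatic carbon, the same change that leads from compound 1 to compound 2, and the surroundings of the place read the same in both pairs. Because a 1.1-fold higher number from compound 1 to compound 2 (0.04 log units; within the scatter) stayed within the scatter, a step of similar size is expected here as well, a 1.1-fold higher number from compound 3 to compound 4 (0.03 log units; within the scatter). Compound 4 is accordingly estimated at 27000 nM, with an expected range running from 13000 nM to 55000 nM. This expectation rests on a single measured pair, so the range is kept wide, and the actual reading for compound 4 in this assay will show whether the change behaves the same way on the core of compound 3.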

Compound 4, half-maximal inhibitory concentration: 26000 nM
The estimate for compound 4 lay 1.0-fold (0.02 log units) above the measured number; the measured number falls inside the stated range.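

In this assay, bromo in place of chloro on the aromatic carbon goes with a 1.0-fold higher number from compound 3 to compound 4 (0.02 log units; within the scatter), and this step matches the one seen on the other core: the same change on two cores in this assay, a 1.1-fold higher number (0.04 log units; within the scatter) from compound 1 to compound 2 and a 1.0-fold higher number (0.02 log units; within the scatter) from compound 3 to compound 4, 1.0-fold (0.02 log units) apart, within the scatter of two such steps
Fluoro in place of bromo goes with a 1.0-fold higher number from compound 2 to compound 4 (0.02 log units; within the scatter), and it also agrees with its earlier counterpart: the same change on two cores in this assay, a 1.1-fold higher number (0.04 log units; within the scatter) from compound 1 to compound 3 and a 1.0-fold higher number (0.02 log units; within the scatter) from compound 2 to compound 4, 1.0-fold (0.02 log units) apart, within the scatter of two such steps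
Among these compounds, both changes therefore read the same on the two cores, but every step lies within the scatter, so this shows only that neither exchange produced a step that could be told from the scatter on these cores, not that a larger step would carry over from one core to another in the same way.

The compounds shown vary only chloro and bromo in the 4-halophenyl group and bromo and fluoro at the second place, all of them halogens, so it remains open whether a methoxy group, an amine or a carboxylic acid at either place would give a step beyond the scatter. On these data alone, it also remains open whether such a step would then carry from one core to another, and whether the nitro group and the unsubstituted phenyl group, the same in all four compounds, matter to the reading.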